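The compounds below may be only part of what the source reports. "The series", "measured", "known", "first", "only" and "open" are said of these compounds alone.

Among the measured compounds shown here, compound 1 `CCOC(=O)c1ccc(NC(=O)N2CC2C#N)cc1` holds the lower of the two numbers measured so far: in a functional assay on RPMI-8226 cells (Homo sapiens) for inhibition (on this read-out higher numbers stand for weaker inhibition and lower numbers for stronger inhibition), compound 1 gives 3000 nM, while compound 2 `CNC(=O)N1CC1C#N` gives 26000 nM, a gap beyond the usual scatter of this kind of measurement. Compound 3 `N#CC1CN1C(=O)Nc1ccc(C(F)(F)F)cc1` differs from compound 1 in one place: trifluoromethyl in place of ethoxycarbonyl on an aromatic carbon. For the measured compounds named here, no measured pair shows this change, so only a small step is expected, a 1.2-fold lower number from compound 1 to compound 3 (0.08 log units; within the scatter), lying within the usual scatter in either direction. Compound 3 is therefore estimated at 2500 nM, with a range from 800 nM to 8000 nM.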

Compound 3, half-maximal inhibitory concentration: 7800 nM
Beside the measured number, compound 3's estimate is 3.1-fold (0.49 log units) below it, within the range that was stated.
By their numbers in this assay, from the lowest: compound 1; then compound 3; then compound 2.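

In this assay, this place on the aromatic ring is not indifferent to its group: trifluoromethyl in place of ethoxycarbonyl gives a 2.6-fold higher number from compound 1 to compound 3 (0.41 log units; beyond the scatter) and so somewhat weaker inhibition. Ethoxycarbonyl brings hydrogen-bond acceptors and trifluoromethyl brings none, but this one pair cannot show whether that difference matters. Nothing measured here explains the step. As far as these compounds go, whether a carboxylic acid, an amine or a longer ester chain at this same place would match or improve on compound 1 remains open.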